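Amide in place of the acid on the shared core

The source may hold more compounds than are shown below. What is called first, only, known or untested is meant among the compounds shown, and "the series" means these compounds.

Working notes on the series. The shared core of compound 1 `O=C(O)COc1ccc(NCc2cccc(Oc3ccccc3)c2)cc1` carries a carboxymethoxy group, and in a functional assay on CHO cells for agonist activity at Free fatty acid receptor 1 (Homo sapiens) (on this read-out lower numbers stand for an effect already at smaller amounts and higher numbers for an effect only at larger amounts of compound), compound 1 gives 2040 nM. Compound 2 `CC(C)(Oc1ccc(NCc2cccc(Oc3ccccc3)c2)cc1)C(=O)O` carries a 1-carboxy-1-methylethoxy group instead; in this assay compound 2 gives only a limit, < 10000 nM. Compound 3 `CC(CC(=O)O)c1ccc(NCc2cccc(Oc3ccccc3)c2)cc1` carries a 1-(carboxymethyl)ethyl group and in this assay gives 126 nM, the lowest of the two numbers, through the step of a 16-fold lower number from compound 1 to compound 3 (1.21 log units; beyond the scatter). The steps a step that the limit leaves unreadable from compound 1 to compound 2 and a step that the limit leaves unreadable from compound 2 to compound 3 stay unreadable because of the limit of < 10000 nM in this assay, at which 1 of the 3 values shown sits.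

Compound 4 `O=C(CCc1ccc(NCc2cccc(Oc3ccccc3)c2)cc1)N1CCCC1` replaces the acid of compound 3 with an amide: 2-((pyrrolidin-1-yl)carbonyl)ethyl in place of 1-(carboxymethyl)ethyl on an aromatic carbon. Going by the values given here, no measured step covers this change; every measured compound keeps a carboxylic acid, and the measured steps compare only the groups that carry it, so the estimate is loosely anchored. For compound 4 the expected step is a 24-fold higher number from compound 3 to compound 4 (1.38 log units; beyond the scatter), towards a higher number. Compound 4 is thus estimated at 3000 nM, within a range from 400 nM to 20000 nM.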

Compound 4, half-maximal effective concentration: 115 nM
Compound 4: middle estimate off by 26-fold (1.42 log units), on the high side; measured number below the stated range.
By their numbers in this assay, from the lowest: compounds 4 and 3 (each within the scatter of the next); then compound 1.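

In this assay, a carboxylic acid proves dispensable at this position, as 2-((pyrrolidin-1-yl)carbonyl)ethyl, with 0 hydrogen-bond donors, takes the place of 1-(carboxymethyl)ethyl in a 1.1-fold lower number from compound 3 to compound 4 (0.04 log units; within the scatter). The amide also stands well apart from the carboxymethoxy group, with an 18-fold lower number from compound 1 to compound 4 (1.25 log units; beyond the scatter), so a low number in this series no longer goes only with an acid-bearing compound. Compound 2 gives only a limit, and the step from compound 2 to compound 4 cannot be read: the limit of < 10000 nM in this assay, at which 1 of the 4 values shown sits.

As far as these compounds go, the change swaps the acid for the amide, adds the pyrrolidine ring and drops the branching methyl all at once, so the share of each stays open. Also open, from the compounds shown here alone, is whether a simple primary amide, a dimethylamide or a piperidine amide would match the pyrrolidine amide here.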